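Removing Two Chlorines from the Aryl Arm, a Second Time

A few compounds are considered here, and "the series" means these few. Any claim that something is new, unique, unknown or untested is made for them only; others in the source may bear on it.

Compound 2 `Cc1nc(-c2ccc(Cl)cc2)sc1C(=O)CSc1nc(-c2ccc(Cl)c(Cl)c2)c(C#N)c(=O)[nH]1` is the anchor of this small set. In a functional assay on U-87MG ATCC cells for antiproliferative activity against U-87 MG (Homo sapiens), read by MTT assay, with a stated time of 48 h, tested at 5 uM (a lower number here means a stronger effect, a higher number a weaker effect of the compound at the concentration tested), compound 2 gives 101%, a number that points to little or no effect at the tested concentration. Compound 1 `Cc1nc(-c2ccc(Cl)cc2)sc1C(=O)CSc1nc(-c2ccccc2)c(C#N)c(=O)[nH]1` differs from it in one place: phenyl in place of 3,4-dichlorophenyl on an aromatic carbon. In this assay compound 1 gives 88.9%, so the step of a number 12.1 percentage points lower from compound 2 to compound 1 (beyond the scatter) is a modest gain in effect that lies beyond the scatter. Compound 3 `COc1ccc(-c2nc(C)c(C(=O)CSc3nc(-c4ccc(Cl)c(Cl)c4)c(C#N)c(=O)[nH]3)s2)cc1` keeps the dichlorophenyl arm of compound 2 but differs in the other half of the molecule: methoxy in place of chloro on an aromatic carbon. In this assay compound 3 gives 101%, and the step of no change at the digits printed from compound 2 to compound 3 (within the scatter) is within the scatter, so compounds 2 and 3 stand level.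

Compound 4 `COc1ccc(-c2nc(C)c(C(=O)CSc3nc(-c4ccccc4)c(C#N)c(=O)[nH]3)s2)cc1` has not yet been measured. It is derived from compound 3 by the same change that turned compound 2 into compound 1: phenyl in place of 3,4-dichlorophenyl on an aromatic carbon. The surroundings of the change are the same word for word in both pairs, so this is the same change, made on the core of compound 3 rather than that of compound 2. For the measured compounds named here, with only one precedent to lean on, and because that precedent is a number 12.1 percentage points lower from compound 2 to compound 1 (beyond the scatter), the step from compound 3 is expected to be a number 11 percentage points lower from compound 3 to compound 4 (beyond the scatter). Compound 4 is therefore expected to give about 90% in this assay, with a likely range from 78% to 102%. Whether a change seen once carries over to a core altered elsewhere is exactly what the coming measurement will show.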

Compound 4, a percentage reported as activity, at one concentration (the size of the read-out at that concentration, not a potency): 99%
Compound 4: middle estimate off by 9 percentage points, on the low side; measured number inside the range.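

On the core of compound 3, putting phenyl in place of 3,4-dichlorophenyl gives a number 2 percentage points lower from compound 3 to compound 4 (within the scatter) in this assay, while on the core of compound 2 the same change gave a number 12.1 percentage points lower from compound 2 to compound 1 (beyond the scatter), and one step lies within the scatter while the other lies beyond it, yet the two steps cannot be told apart: the same change on two cores in this assay, a number 12.1 percentage points lower (beyond the scatter) from compound 2 to compound 1 and a number 2 percentage points lower (within the scatter) from compound 3 to compound 4, 10.1 percentage points apart, within the scatter of two such steps. The second change, methoxy in place of chloro, can be read the same way, with a number 10.1 percentage points higher from compound 1 to compound 4 (beyond the scatter) among the phenyl compounds, and it too stays in agreement with its earlier counterpart on the dichlorophenyl compounds: the same change on two cores in this assay, no change at the digits printed (within the scatter) from compound 2 to compound 3 and a number 10.1 percentage points higher (beyond the scatter) from compound 1 to compound 4, 10.1 percentage points apart, within the scatter of two such steps. So the data show no firm sign that either core alters the effect of the change, but two pairs do not show that the change carries over reliably, and the modest gain seen with compound 1 is not confirmed by compound 4.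

The compounds shown leave open what an amine or a carboxylic acid on the aryl arm, or a longer chain in place of the methoxy group, would do in this assay. They also leave open what happens when the nitrile, which all four compounds share, gives way to another group such as an amide.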